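This account rests on a few compounds, and the source may have more. Where it says the series, first, only, none or still open, it means among the compounds named here.

Measured in a functional assay on MCF7 cells (Homo sapiens) for cytotoxicity, read by MTT assay, with a stated time of 48 h; a higher number here means a weaker inhibitor of growth, a lower number a stronger inhibitor of growth:
- compound 1 `CC(C)n1c(C(F)(F)F)nc2cc(Cl)c(Cl)cc21`: 70500 nM
- compound 2 `FC(F)(F)c1nc2cc(Cl)c(Cl)cc2n1Cc1ccccc1`: 8700 nM
- compound 3 `O=[N+]([O-])c1cccc(Cn2c(C(F)(F)F)nc3cc(Cl)c(Cl)cc32)c1`: 60000 nM

Compound 2 has the lowest number of the three, and its steps to both other compounds lie beyond the scatter. The next compound is compound 4 `FC(F)(F)c1nc2cc(Cl)c(Cl)cc2n1C1CCCC1`, with cyclopentyl in place of benzyl on an aromatic nitrogen.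

The most relevant measured step is an 8.1-fold lower number from compound 1 to compound 2 (0.91 log units; beyond the scatter), with benzyl in place of isopropyl on that same nitrogen. The other step, a 6.9-fold higher number from compound 2 to compound 3 (0.84 log units; beyond the scatter), bears less directly: it adds nitro to an aromatic carbon and keeps the benzyl. Neither step involves cyclopentyl, so the comparison with isopropyl is only an analogy.

In this assay, for the measured compounds named here, a modest move to a higher number is expected on leaving benzyl, probably no larger than the step between the isopropyl and benzyl compounds. The expected change is a 3.4-fold higher number from compound 2 to compound 4 (0.54 log units; beyond the scatter). For compound 4 the estimate is 30000 nM, with an expected range of 10000 nM to 80000 nM.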

Compound 4, concentration for 50% growth inhibition: 21000 nM
The estimate for compound 4 lay 1.4-fold (0.15 log units) above the measured number; the measured number falls inside the stated range.
By their numbers in this assay, from the lowest: compound 2; then compound 4; then compounds 3 and 1 (each within the scatter of the next).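

In this assay, cyclopentyl on the aromatic nitrogen gives a 2.4-fold higher number from compound 2 to compound 4 (0.38 log units; beyond the scatter) and thus does not match benzyl, yet this step is smaller than the one seen between the isopropyl and benzyl compounds. Cyclopentyl in place of isopropyl gives a 3.4-fold lower number from compound 1 to compound 4 (0.53 log units; beyond the scatter) and shows that a lower number at this nitrogen does not require a six-membered aromatic ring, although benzyl remains lowest among the three unsubstituted nitrogen groups compared here. No supporting evidence accompanies this order, which therefore stays purely descriptive.

Open, going by these compounds, is whether a cyclohexyl group, a longer alkyl chain or a chain ending in an amine or carboxylic acid would follow the same order at this nitrogen. Also open, on these data alone, is whether a methoxy group or a fluorine on the benzyl ring would behave as nitro does.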